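A few compounds are considered here, and "the series" means these few. Any claim that something is new, unique, unknown or untested is made for them only; others in the source may bear on it.

In a physicochemical assay for lipophilicity, measured as octanol-water partition, at pH 7.4 (a lower number here means a more polar compound, a higher number a more lipophilic compound), compound 1 `O=C([C@H](O)CS(=O)(=O)c1ccc2cc(Cl)ccc2c1)N1CCC(N2CCOC2=O)CC1` gives 1.75 and compound 2 `O=C([C@H](O)CS(=O)(=O)c1ccc2cc(Cl)ccc2c1)N1CCC(N2CCCC2=O)CC1` gives 1.96 and the two lie within the scatter of each other. In compound 3 `O=C([C@H](O)CS(=O)(=O)c1ccc2cc(Cl)ccc2c1)N1CCC(N2CCCCCC2=O)CC1` 2-oxoazepan-1-yl stands in place of the 2-oxopyrrolidin-1-yl of compound 2 on a saturated ring carbon (2-oxoazepan-1-yl in place of 2-oxopyrrolidin-1-yl on a saturated ring carbon). Among the compounds with values here, the one measured step at this place is a number 0.21 log units higher from compound 1 to compound 2 (within the scatter) and it exchanges a different ring, so it sets the size only loosely. With carbon added to the ring, the expected move in this assay is a number 0.54 log units higher from compound 2 to compound 3 (beyond the scatter) as an estimate beyond the scatter. Compound 3 is estimated at 2.5 (range 2.15 to 2.9).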

Compound 3, distribution coefficient: 2.52
Compound 3: middle estimate off by 0.02 log units, on the low side; the measured number falls inside the stated range.
By their numbers in this assay, from the lowest: compounds 1 and 2 (each within the scatter of the next); then compound 3.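

In this assay the group on this saturated ring carbon now separates compounds beyond the scatter: 2-oxoazepan-1-yl in place of 2-oxopyrrolidin-1-yl gives a number 0.56 log units higher from compound 2 to compound 3 (beyond the scatter) in this series. Against 2-oxo-1,3-oxazolidin-3-yl the same group gives a number 0.77 log units higher from compound 1 to compound 3 (beyond the scatter) and so the position shows a spread that the first pair alone did not. Nothing measured here accounts for the rise.

Whether the number climbs steadily with ring size stays open, since 2-oxopiperidin-1-yl is not among the compounds shown. Going by these compounds, how a tertiary amine or a carboxylic acid would read at this carbon also stays open.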